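A few compounds are considered here, and "the series" means these few. Any claim that something is new, unique, unknown or untested is made for them only; others in the source may bear on it.

Three compounds share one core and differ only in the group carried on a double-bonded ring carbon. Compound 1 `Cc1ccc(NC2=CC(=O)c3nc4n(c3C2=O)[C@H]2OC[C@@H](O)[C@H]2OC4)cc1` gives 1660 nM in a functional assay on MCF7 cells (Homo sapiens) for inhibition, read by sulforhodamine B assay; on this read-out lower numbers stand for stronger inhibition and higher numbers for weaker inhibition. Compound 2 `O=C1C=C(Nc2cccc(Cl)c2)C(=O)c2c1nc1n2[C@H]2OC[C@@H](O)[C@H]2OC1` gives 4720 nM in this assay, and compound 3 `COc1ccc(NC2=CC(=O)c3nc4n(c3C2=O)[C@H]2OC[C@@H](O)[C@H]2OC4)cc1` gives 5420 nM in this assay. The number for compound 3 is the highest of the three, but its gap to compound 2 lies within the scatter, while a 3.3-fold higher number from compound 1 to compound 3 (0.51 log units; beyond the scatter) and a 2.8-fold higher number from compound 1 to compound 2 (0.45 log units; beyond the scatter) are both modest and beyond the scatter.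

Compound 4 `CCCN(CCC)C1=CC(=O)c2nc3n(c2C1=O)[C@H]1OC[C@@H](O)[C@H]1OC3` has not been measured. Its change from compound 3 is dipropylamino in place of (4-methoxyphenyl)amino on a double-bonded ring carbon. Within the data shown here, none of the measured steps tests a change of this kind: each of them swaps one substituted phenyl group for another on the amine nitrogen, and a 1.1-fold higher number from compound 2 to compound 3 (0.06 log units; within the scatter) lies within the scatter. With no direct guidance, the expectation is wide and rests on the modest scale of the changes seen so far. Compound 4 is expected to give about 8000 nM in this assay, within a likely range of 2000 nM to 30000 nM. This estimate amounts to a 1.5-fold higher number from compound 3 to compound 4 (0.17 log units; within the scatter), a step not expected to go clearly beyond the scatter.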

Compound 4, half-maximal inhibitory concentration: > 16000 nM
Compound 4 ended at the assay's limit; the forecaster's own chance of this, stated with the estimate: 15%; middle value at least 2.0-fold (0.30 log units) away from the limit.
By their numbers in this assay, from the lowest: compound 1; then compounds 2 and 3 (each within the scatter of the next). At a limit, above all of these: compound 4.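

Earlier steps only swapped one substituted phenyl group for another on the amine nitrogen, whereas dipropylamino on this double-bonded ring carbon brings no ring and no hydrogen-bond donor, and inhibition weakens in this assay. The change gives an at least 2.9-fold higher number from compound 3 to compound 4 (0.47 log units; beyond the scatter), an at least 3.3-fold higher number from compound 2 to compound 4 (0.53 log units; beyond the scatter) and an at least 9.6-fold higher number from compound 1 to compound 4 (0.98 log units; beyond the scatter), each beyond the scatter, so this position does not accept every amine equally. Compound 4 stands at a limit rather than at a true number, so each step is only a lower bound on the loss: the limit of > 16000 nM in this assay, at which 1 of the 4 values shown sits.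

Dipropylamino removes the ring and the amine hydrogen together, and the compounds shown do not separate these two changes. A propylamino group, which keeps the amine hydrogen without a ring, or a benzylamino group, which keeps both with a carbon spacer, would help to tell them apart.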